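A few compounds are considered here, and "the series" means these few. Any claim that something is new, unique, unknown or untested is made for them only; others in the source may bear on it.

Measured compounds:
compound 1, `Cc1nn(-c2ccccn2)c2cc(-c3ccc(CC(C)(C)C(=O)O)cc3)ccc12`, 18%
compound 2, `Cc1nn(-c2ccccn2)c2cc(-c3ccc(CCCC(=O)O)cc3)ccc12`, 117%
compound 3, `Cc1nn(-c2ccccn2)c2cc(-c3ccc([C@H]4C[C@@H]4C(=O)O)cc3)ccc12`, 6%; 10% (2 entries)

All three share one core and differ only in the acid-bearing group on the outer ring. In a functional assay on cells for agonist activity at Free fatty acid receptor 1 (Mus musculus), read by FLIPR and calcium flux, with a stated time of 5 min (on this read-out higher numbers stand for larger maximal responses and lower numbers for smaller maximal responses), compound 2 gives 117%, the highest of the two single numbers; compound 1 gives 18%, and the step of a number 99 percentage points higher from compound 1 to compound 2 (beyond the scatter) is large. Going by the values given here, compound 3 was measured more than once, (the several entries of compound 3 in this assay, 6%; 10% (2 entries)), and both of its entries sit far beneath the number for compound 2, though no single step is computed for that pair.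

Compound 4, `Cc1nn(-c2ccccn2)c2cc(-c3ccc([C@H]4C[C@H]4C(=O)O)cc3)ccc12`, has not yet been measured. It differs from compound 2 in one place: 2-carboxycyclopropyl in place of 3-carboxypropyl on an aromatic carbon. Compound 4 is the other stereoisomer of the same cyclopropyl acid seen in compound 3. Among the compounds with values here, the only measured step, the one from compound 1 to compound 2, shows that reshaping this acid-bearing group can move the maximal response by a great deal, and the entries for compound 3 show that the ring form can give very small responses. A large drop is therefore expected, with wide uncertainty, and compound 4 is estimated at 35%, between 5% and 100%. That corresponds to an expected step of a number 82 percentage points lower from compound 2 to compound 4 (beyond the scatter).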

Compound 4, largest response reached (reported as efficacy), in percent of the reference or control that the assay uses: 81%
Estimate against measurement, compound 4: 46 percentage points below; the range from low to high includes it.
By their numbers in this assay, from the lowest: compound 1; then compound 4; then compound 2.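

Putting 2-carboxycyclopropyl in place of 3-carboxypropyl gives a number 36 percentage points lower from compound 2 to compound 4 (beyond the scatter) in this assay, so at this position on the outer ring, the ring form can lower the maximal response without removing most of it. Against the 2-carboxy-2-methylpropyl group, the same ring gives a number 63 percentage points higher from compound 1 to compound 4 (beyond the scatter), so a group of this ring type can retain far more response than the branched chain. Compound 4 gives 81% and compound 3 gives 6%; 10% (2 entries), which shows that the ring alone does not fix the response and that configuration matters here: the fact that compounds 3 and 4 differ only in the configuration as drawn

Open, as far as these compounds go, is whether a longer chain such as 4-carboxybutyl, or a cyclobutane ring carrying the carboxylic acid, would match compound 2. These numbers also describe only the largest response, not how much compound is needed to reach it.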